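The compounds below may be only part of what the source reports. "The series", "measured", "known", "first", "only" and "open" are said of these compounds alone.

Measured compounds:
compound 1 `CO[C@H]1CC[C@H](N2CC(=O)Nc3ncc(-c4ccc(C(C)(C)O)nc4)nc32)CC1` – 94%
compound 2 `O=c1[nH]c2ncc(-c3ccc(-c4nc[nH]n4)cc3)nc2n1CCC1CCOCC1` – 93%

In an ADME assay on S9 fraction (Rattus norvegicus) for metabolic stability, with a stated time of 60 min (on this read-out lower numbers stand for a less stable compound and higher numbers for a more stable compound), compound 1 gives 94%, the higher of the two numbers, while compound 2 gives 93%, a gap within the usual scatter. Within the data shown here, no step between measured compounds is at hand for this change.

Compound 3 `CO[C@H]1CC[C@@H](N2CC(=O)Nc3ncc(-c4ccc(C(C)(C)O)nc4)nc32)CC1` is to be measured. It differs from compound 1 as follows: the two compounds have the same atoms and bonds and differ only in configuration as drawn: 2 of 2 stereo elements differ (all stereocentres are inverted: mirror images); a stereocentre at a saturated ring carbon is drawn r in compound 1 and s in compound 3; a stereocentre at a saturated ring carbon is drawn r in compound 1 and s in compound 3.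

With both measured compounds near the top of the read-out in this assay, no step beyond the scatter is expected, leaning slightly downward. The expected step is a number 4 percentage points lower from compound 1 to compound 3 (within the scatter). Compound 3 is estimated at 90%, with a range from 75% to 98%.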

Compound 3, percent of the compound remaining: 87%
Compound 3: the middle estimate sits 3 percentage points above what was measured; the measured number falls inside the stated range.
By their numbers in this assay, from the lowest: compounds 3, 2 and 1 (each within the scatter of the next).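

In this assay, among these compounds, inverting both stereocentres at the saturated ring carbons gives a number 7 percentage points lower from compound 1 to compound 3 (within the scatter), the first step between compounds that differ in one place. Configuration at these stereocentres therefore shifts this read-out by no more than the scatter, and both forms remain stable here. The structural basis of this comparison is clean: the fact that compounds 1 and 3 differ only in the configuration as drawn

From the compounds shown here alone, it remains open whether an amine or a carboxylic acid on the saturated ring would preserve this stability. Going by these compounds, whether the two configurations also match in any other assay is equally open.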